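A few compounds are considered here, and "the series" means these few. Any claim that something is new, unique, unknown or untested is made for them only; others in the source may bear on it.

Of the compounds shown here, two built on a shared core have been tested in a functional assay on DU-145 cells (Homo sapiens) for inhibition, read by sulforhodamine B assay, with a stated time of 48 h; on this read-out lower numbers stand for stronger inhibition of growth and higher numbers for weaker inhibition of growth. Within the data shown here, compound 2, `Nc1cc(N)c2nc(-c3ccccc3)c(NCc3ccc(Cl)c(Cl)c3)nc2c1`, gives 16200 nM in this assay, and this is the only plain number reported so far. For compound 1, `CCOC(=O)[C@H](CCC(=O)O)NC(=O)c1ccc(CNc2nc3cc(N)cc(N)c3nc2-c2ccccc2)cc1`, this assay reports only a limit, < 100000 nM, which is the limit of < 100000 nM in this assay, at which 1 of the 2 values shown sits. Compound 3, `COc1ccc(CNc2nc3cc(N)cc(N)c3nc2-c2ccccc2)cc1`, has not yet been measured. It differs from compound 2 in a single place: 4-methoxyphenyl in place of 3,4-dichlorophenyl on a saturated chain carbon bound to a nitrogen on an aromatic ring. Among the measured compounds shown here, no two measured compounds in this set differ in just one place, so there is no measured step that shows how a change of this kind shifts growth inhibition here, and the expectation for compound 3 rests on compound 2 alone. The step of a 1.5-fold higher number from compound 2 to compound 3 (0.19 log units; within the scatter) is expected to be small, staying within the usual scatter of repeated measurements or at most a little beyond it toward weaker inhibition of growth. In this assay compound 3 is estimated at 25000 nM, with a range running from 8000 nM to 80000 nM.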

Compound 3, concentration for 50% growth inhibition: 21900 nM
For compound 3 the middle estimate is 1.1-fold (0.06 log units) above the measured one; the range from low to high includes it.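

Among these compounds, the change from 3,4-dichlorobenzyl to 4-methoxybenzyl now gives the first measured step at this position in this assay: a 1.4-fold higher number from compound 2 to compound 3 (0.13 log units; within the scatter). Two quite different substituent patterns on this ring, a pair of chlorines and a methoxy group with its oxygen hydrogen-bond acceptor, therefore cannot be told apart on this read-out, and in this one pair the change leaves growth inhibition without a measurable shift. Nothing given here accounts for why the step is this small.

Among the compounds shown here, for compound 1 the read-out gives only a limit, < 100000 nM, and no step to it can be read. Going by these compounds, whether a nitrile or a trifluoromethyl group on this ring, or an amine or a longer chain in place of the benzyl group, would move growth inhibition beyond the scatter remains open.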